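The compounds below may be only part of what the source reports. "The series", "measured", "known", "first", "only" and "open" are said of these compounds alone.

Measured so far in a functional assay on XF498 cells (Homo sapiens) for cytotoxicity; on this read-out higher numbers stand for weaker inhibition and lower numbers for stronger inhibition:
compound 1 `COc1ccc(-c2cc3cc(C)ccc3c(N3CCN(C)CC3)n2)cc1`: 7410 nM
compound 2 `Cc1ccc(-c2cc3cc(C)ccc3c(N3CCN(C)CC3)n2)cc1`: 4470 nM
compound 3 `CN1CCN(c2nc(-c3ccc(Cl)cc3)cc3c(N(C)C)cccc23)CC1`: 7300 nM

In this assay compound 3 gives 7300 nM and so lies within the scatter of both compound 1 and compound 2. The next compound is compound 4 `COc1ccc(-c2cc3c(N(C)C)cccc3c(N3CCN(C)CC3)n2)cc1`, which differs from compound 3 by methoxy in place of chloro on an aromatic carbon and carries methoxy in place of chloro on an aromatic carbon. Going by the values given here, only one measured step bears on this, a 1.7-fold lower number from compound 1 to compound 2 (0.22 log units; within the scatter), which involves methoxy but not chloro. Among the compounds with values here, no measured pair shows the exchange of chloro for methoxy itself. No step beyond the scatter is therefore expected in this assay. The estimated step is a 1.0-fold lower number from compound 3 to compound 4 (0.02 log units; within the scatter) and would stay within the scatter. Compound 4 is expected at 7000 nM, with an estimated range from 3000 nM to 16000 nM.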

Compound 4, half-maximal inhibitory concentration: 10700 nM
For compound 4 the middle estimate is 1.5-fold (0.18 log units) below the measured one; measured number inside the range.
By their numbers in this assay, from the lowest: compounds 2, 3, 1 and 4 (each within the scatter of the next, the first and the last beyond it).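

In this assay, going by these compounds alone, the exchange of 4-chlorophenyl for 4-methoxyphenyl gives a 1.5-fold higher number from compound 3 to compound 4 (0.17 log units; within the scatter) and is the first direct reading of methoxy in place of chloro at this position. Together with a 1.7-fold lower number from compound 1 to compound 2 (0.22 log units; within the scatter) on the core of compound 1, it shows a second exchange on an aromatic carbon para to a large group that stays within the scatter. Nothing measured here gives a reason for this result. Going by these compounds, whether an amine or a carboxylic acid at this position would give a step beyond the scatter remains open, as does whether chloro and methoxy would also match on the core of compound 1.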